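Cyclopentyl to tert-butyl on the ether chain

A few compounds are considered here, and "the series" means these few. Any claim that something is new, unique, unknown or untested is made for them only; others in the source may bear on it.

Measured so far:
compound 1, `COc1cccc(OCCC(C)(C)C)c1C(=O)/C=C/c1ccc(O)cc1`, > 30000 nM
compound 2, `O=C(/C=C/c1ccc(O)cc1)c1c(O)cccc1OCCC1CCCC1`, 3370 nM
compound 3, `CC(C)CCCOc1cccc(O)c1C(=O)/C=C/c1ccc(O)cc1`, 11400 nM

In a functional assay on NCI-H23 cells (Homo sapiens) for antiproliferative activity, read by sulforhodamine B assay (on this read-out higher numbers stand for weaker inhibition of growth and lower numbers for stronger inhibition of growth), compound 2 gives 3370 nM, the lowest of the two numbers shown; the nearest is compound 3 at 11400 nM. Compound 1 reports only a limit, > 30000 nM, which is the assay limit of > 30000 nM in this assay, at which 1 of the 3 values shown sits, and not a number. Compound 4, `CC(C)(C)CCOc1cccc(O)c1C(=O)/C=C/c1ccc(O)cc1`, is not yet measured. It differs from compound 2 by tert-butyl in place of cyclopentyl on a saturated chain carbon, two bonds along the chain from an oxygen on an aromatic ring.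

Among the compounds with values here, one measured step bears on this change: a 3.4-fold higher number from compound 2 to compound 3 (0.53 log units; beyond the scatter). That step also removes the ring from the chain end, and the tert-butyl of compound 4 is close in size and shape to the isobutyl of compound 3. Compound 1 carries a tert-butyl on the same kind of chain but differs elsewhere on the core, and gives only a limit, so it cannot set a number here.

The expected step is therefore in the same direction as the measured one, a weakening: a 2.7-fold higher number from compound 2 to compound 4 (0.43 log units; beyond the scatter) is estimated. For compound 4 the estimate in this assay is 9000 nM, with a range from 3500 nM to 25000 nM.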

Compound 4, concentration for 50% growth inhibition: 3130 nM
Estimate against measurement, compound 4: 2.9-fold (0.46 log units) above, and the stated range ends above it.
By their numbers in this assay, from the lowest: compounds 4 and 2 (each within the scatter of the next); then compound 3. At a limit, above all of these: compound 1.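

In this assay, tert-butyl in place of cyclopentyl on a saturated chain carbon, two bonds along the chain from an oxygen on an aromatic ring, gives a 1.1-fold lower number from compound 2 to compound 4 (0.03 log units; within the scatter), so a ring at the chain end is not required to reach the level of compound 2. The earlier 3.4-fold higher number from compound 2 to compound 3 (0.53 log units; beyond the scatter) came with loss of the ring. Within the data shown here, a step also appears with no ring in either compound, with tert-butyl in place of isobutyl: a 3.6-fold lower number from compound 3 to compound 4 (0.56 log units; beyond the scatter). Compound 1 stands at a limit and not at a number, so hydrogen in place of methyl on an oxygen on an aromatic ring can only be read as an at least 9.5-fold lower number from compound 1 to compound 4 (0.98 log units; beyond the scatter): the limit of > 30000 nM in this assay, at which 1 of the 4 values shown sits.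

On these data alone, only tert-butyl, isobutyl and cyclopentyl have been seen at this place, so it stays open whether a chain end carrying an amine or a carboxylic acid, or a phenyl ring in place of cyclopentyl, would fit the same pattern. Among these compounds, compound 1 is also the only compound with methyl on that oxygen, which leaves open how large the change from methyl to hydrogen is when its value is a number, and whether it holds with cyclopentyl at the chain end.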